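Fluoro for Methyl on the Benzyl Ring of Compound 1

The source may hold more compounds than are shown below. What is called first, only, known or untested is meant among the compounds shown, and "the series" means these compounds.

Compound 1 `C/C=C/C(=O)N(Cc1ccc(OC)c(C)c1)c1cc(OC)c(OC)c(OC)c1` carries a crotonamide on the nitrogen and a 4-methoxy-3-methylphenyl group on the benzyl arm. Among the compounds with values here, in a functional assay on KYSE-450 cells (Homo sapiens) for inhibition, read by MTT assay, with a stated time of 48 h (on this read-out lower numbers stand for stronger inhibition and higher numbers for weaker inhibition), compound 1 gives 32900 nM, the higher of the two numbers measured so far. Compound 2 `C#CC(=O)N(Cc1ccc(OC)c(O)c1)c1cc(OC)c(OC)c(OC)c1` differs from it in more than one place, and in this assay compound 2 gives 570 nM, a much stronger inhibition; since the two compounds differ in several places at once, the comparison shows only what the two values show and cannot be traced to any single change.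

Compound 3 `C/C=C/C(=O)N(Cc1ccc(OC)c(F)c1)c1cc(OC)c(OC)c(OC)c1` is the direct neighbour of compound 1: fluoro in place of methyl on an aromatic carbon. Within the data shown here, the change is small in size and in count, and nothing measured so far speaks to what it does. The step from compound 1 to compound 3 is therefore expected to stay within the usual scatter, without a clear direction, a 1.3-fold lower number from compound 1 to compound 3 (0.12 log units; within the scatter). On that basis compound 3 is estimated to give 25000 nM in this assay, with a plausible range from 8000 nM to 80000 nM.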

Compound 3, half-maximal inhibitory concentration: 1400 nM
Compound 3: middle estimate off by 18-fold (1.25 log units), on the high side; the measured number lies below the stated range.
By their numbers in this assay, from the lowest: compound 2; then compound 3; then compound 1.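

The carbon on the benzyl arm ortho to a methoxy group is a sensitive place in this assay: fluoro in place of methyl there gives a 24-fold lower number from compound 1 to compound 3 (1.37 log units; beyond the scatter), although a single heavy atom leaves and a single heavy atom enters. Compound 1 and compound 2 differ in several places and could not tie any change in this assay to one site, whereas this pair leaves the crotonamide, the methoxy group and the rest of the core of compound 1 untouched and isolates the effect of this one exchange. The data offer no measurement that accounts for the size of this step.

As far as these compounds go, it remains open whether the step reflects the arrival of fluoro, the departure of methyl or both, a question that a compound with chloro or plain hydrogen on this carbon would help to answer. Within the data shown here, it is equally open whether the exchange of methyl for fluoro would give a step of similar size with a different group on the nitrogen, such as the one carried by compound 2.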